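Swapping a fluorinated aryl ether for a cyclopropyl ether

The compounds below may be only part of what the source reports. "The series", "measured", "known", "first", "only" and "open" are said of these compounds alone.

Three compounds share a common core and were tested in a functional assay on MV4-11 cells (Homo sapiens) for antiproliferative activity, read by CCK-8 assay, with a stated time of 72 h; on this read-out lower numbers stand for stronger inhibition and higher numbers for weaker inhibition. Compound 1 `Cn1cc(-c2cc(C(C)(C)O)ccc2OC2CC2)c2cc(C(=O)NCCCCCCC(=O)NO)[nH]c2c1=O` gives 220 nM. Compound 3 `Cn1cc(-c2cc(C(C)(C)O)ccc2Oc2ccc(F)cc2F)c2cc(C(=O)NCCCCCCC(=O)NO)[nH]c2c1=O` gives 250 nM. Compound 2 `Cn1cc(-c2cc(C(C)(C)O)ccc2Oc2ccc(F)cc2F)c2cc(C(=O)NCc3ccc(C(=O)Nc4ccccc4N)cc3)[nH]c2c1=O` gives 90 nM, the lowest number of the three. Compound 1 and compound 3 differ in one place, (cyclopropyl in place of 2,4-difluorophenyl on an oxygen on an aromatic ring), and this change produced a 1.1-fold lower number from compound 3 to compound 1 (0.06 log units; within the scatter). Compound 2 and compound 3 differ in more than one place, and the difference between them is not broken down here.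

The unmeasured compound 4 `Cn1cc(-c2cc(C(C)(C)O)ccc2OC2CC2)c2cc(C(=O)NCc3ccc(C(=O)Nc4ccccc4N)cc3)[nH]c2c1=O` is made from compound 2 by the same change, (cyclopropyl in place of 2,4-difluorophenyl on an oxygen on an aromatic ring). Because the earlier step of a 1.1-fold lower number from compound 3 to compound 1 (0.06 log units; within the scatter) barely moved the number, the step from compound 2 to compound 4 is expected to be small as well, about a 1.1-fold lower number from compound 2 to compound 4 (0.02 log units; within the scatter). Compound 4 is therefore estimated at 85 nM, most likely between 40 nM and 180 nM in this assay.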

Compound 4, half-maximal inhibitory concentration: 40 nM
Compound 4: middle estimate off by 2.1-fold (0.33 log units), on the high side; the range from low to high includes it.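

In this assay, placing cyclopropyl where 2,4-difluorophenyl stood on the oxygen gave a 2.3-fold lower number from compound 2 to compound 4 (0.35 log units; beyond the scatter). Set beside the same change on the other core, this step cannot be told apart from the earlier one: the same change on two cores in this assay, a 1.1-fold lower number (0.06 log units; within the scatter) from compound 3 to compound 1 and a 2.3-fold lower number (0.35 log units; beyond the scatter) from compound 2 to compound 4, 2.0-fold (0.30 log units) apart, within the scatter of two such steps So the change carried across these two cores with no clear dependence on the core, but two pairs cannot show that the larger step is a real core effect, nor that the change would behave the same way on any further core.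

The compounds shown leave open how a methyl group or an unsubstituted phenyl ring on that oxygen would read on either core. They also leave open whether a longer chain there would keep the number in the same range.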